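The source may hold more compounds than are shown below. What is called first, only, known or untested is meant among the compounds shown, and "the series" means these compounds.

In a functional assay on L02 cells (Homo sapiens) for inhibition, read by Griess assay, with stated times of 1 h and 24 h (a higher number here means a weaker inhibitor, a lower number a stronger inhibitor), compound 1 `C(=C/c1ccco1)\c1nc(NC2CC2)c2sccc2n1` gives > 1000000 nM, which is a limit of the assay rather than a measured number. Compound 2 `C(=C/c1ccco1)\c1nc(NCc2ccccc2)c2sccc2n1` in turn gives > 1000000 nM, again a limit. The step that the two limits leave unreadable from compound 1 to compound 2 is therefore not readable in size. Compound 3 `COc1cc(/C=C/c2nc(N(C)C)c3sccc3n2)cc(OC)c1OC` stands at > 1000000 nM in this assay, once more a limit and not a number. Every measured value in the set sits at the limit of > 1000000 nM in this assay, at which 3 of the 3 values shown sit, so compound 3 cannot be ranked against compound 1 or compound 2: it shares their limit and nothing more can be said of where it stands.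

Compound 4 `COc1cc(/C=C/c2nc(Nc3ccc(O)cc3)c3sccc3n2)cc(OC)c1OC` differs from compound 3 by (4-hydroxyphenyl)amino in place of dimethylamino on an aromatic carbon. Going by the values given here, no measured step bears on this change. Among the compounds with values here, the single step between measured compounds concerns a different position on the shared core, and its size is itself hidden by the two limits. The expectation for compound 4 can therefore rest only on the fact that compound 3 and its two companions all sit at the same limit. Compound 4 is expected to remain close to that limit, with an estimated step of an at least 1.6-fold lower number from compound 3 to compound 4 (0.22 log units; that floor lies within the scatter) from compound 3. Compound 4 is thus estimated at 600000 nM in this assay, within a range from 100000 nM to 3000000 nM.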

Compound 4, half-maximal inhibitory concentration: > 1000000 nM
Compound 4 gave a limit, no number (the forecaster's own chance of this, stated with the estimate: 70%); at least 1.6-fold (0.22 log units) between middle value and limit.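

In this assay, from the compounds shown here alone, compound 3 and compound 4 both end at a limit and not at a number, so no step can be read between them, and the size of the exchange of dimethylamino for (4-hydroxyphenyl)amino stays unknown. The compounds shown leave open whether any change on the shared core yields a measurable inhibition, as every result stands at one value: the limit of > 1000000 nM in this assay, at which 4 of the 4 values shown sit.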